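The compounds below may be only part of what the source reports. "The series", "measured", "known", "first", "only" and "open" are said of these compounds alone.

Compound 1 `CCn1c(NC2CCOCC2)nc2ccsc2c1=O` gives 430 nM in an assay on cells for inhibition of high affinity 3',5'-cyclic-AMP phosphodiesterase 7A (Homo sapiens), read by scintillation counting and cAMP accumulation, with a stated time of 30 min; on this read-out higher numbers stand for weaker inhibition and lower numbers for stronger inhibition.
Compound 2 `CCNc1nc2ccsc2c(=O)n1CC` gives 2900 nM in this assay.
Compound 3 `CCn1c(N[C@H]2CC[C@H](C(=O)O)CC2)nc2ccsc2c1=O` gives 1300 nM in this assay.

Compound 2 stands highest of the three numbers in this assay; compound 3 is nearest, compound 1 furthest. For the measured compounds named here, the only single-point step measured so far is a 6.7-fold higher number from compound 1 to compound 2 (0.83 log units; beyond the scatter), a modest step beyond the scatter, in which a ring on the nitrogen was exchanged for ethyl. Compound 4 `CCn1c(NC2CC2)nc2ccsc2c1=O` differs from compound 2 by cyclopropyl in place of ethyl on a nitrogen on an aromatic ring. The step of a 6.7-fold higher number from compound 1 to compound 2 (0.83 log units; beyond the scatter) bears on this change, since it runs the other way, from ethyl back to a ring substituent on the same nitrogen, though the three-membered ring of carbon only entering here is not the oxan-4-yl that left there. The number for compound 4 in this assay is therefore expected to come out lower than that of compound 2, by a modest step, a 1.9-fold lower number from compound 2 to compound 4 (0.29 log units; within the scatter), smaller than the step seen for the larger ring. Compound 4 is estimated at 1500 nM, within 600 nM to 4000 nM.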

Compound 4, half-maximal inhibitory concentration: 2600 nM
For compound 4 the middle estimate is 1.7-fold (0.24 log units) below the measured one; low and high end bracket the measured number.
By their numbers in this assay, from the lowest: compound 1; then compounds 3, 4 and 2 (each within the scatter of the next, the first and the last beyond it).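

In this assay the change from ethylamino to cyclopropylamino gives a 1.1-fold lower number from compound 2 to compound 4 (0.05 log units; within the scatter) and so, for this pair, a three-membered ring of carbon only on this nitrogen does not set compound 4 apart from the open ethyl chain. The difference from oxan-4-yl remains, at a 6.0-fold higher number from compound 1 to compound 4 (0.78 log units; beyond the scatter) and beyond the scatter, which ties the lower number of compound 1 to that particular ring among these three substituents and not to the presence of any ring. No measurement available here accounts for this difference.

Still open, from the compounds shown here alone, is whether the size of the oxan-4-yl ring or its ring oxygen carries the difference. Cyclohexyl, with carbon in place of that oxygen, and piperidin-4-yl, with an amine there, would separate the two on this nitrogen.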